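This account rests on a few compounds, and the source may have more. Where it says the series, first, only, none or still open, it means among the compounds named here.

Measured so far:
Compound 1 `CCN(CCNC(=O)c1cc(Cl)c(N)cc1OC)Cc1ccccc1`: 0.31 mg/kg
Compound 2 `COc1cc(N)c(Cl)cc1C(=O)NCCN(C)C(C)c1ccccc1`: 1 mg/kg

In a functional assay on the whole organism with Rattus norvegicus as the target (on this read-out higher numbers stand for an effect only at larger amounts of compound and lower numbers for an effect already at smaller amounts), compound 2 gives 1 mg/kg, the higher of the two numbers. Compound 1 gives 0.31 mg/kg, and this gap lies beyond the usual scatter, so compound 2 needs the larger dose. The next compound, compound 3 `COc1cc(N)c(Cl)cc1C(=O)NCCN(C)CC1CCCCC1`, has not yet been measured. It carries cyclohexylmethyl in place of 1-phenylethyl on an amine nitrogen, so the aromatic ring gives way to a non-aromatic one. Within the data shown here, no measured pair isolates this kind of swap, which leaves the expectation uncertain. In this assay, a moderate shift towards larger doses is expected, beyond the scatter, with the estimated step being a 3.0-fold higher number from compound 2 to compound 3 (0.48 log units; beyond the scatter). For compound 3 the estimated value is 3 mg/kg, with an expected range from 0.6 mg/kg to 15 mg/kg.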

Compound 3, dose for half-maximal effect: 3 mg/kg
For compound 3 middle estimate and measured number coincide at the digits printed; measured number inside the range.
By their numbers in this assay, from the lowest: compound 1; then compound 2; then compound 3.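

Among these compounds, this is the first step measured at this place on the amine nitrogen: in this assay, cyclohexylmethyl in place of 1-phenylethyl gives a 3.0-fold higher number from compound 2 to compound 3 (0.48 log units; beyond the scatter). The dose needed therefore responds to the group on this nitrogen, and here the six-membered non-aromatic ring does not stand in for the six-membered aromatic ring without a change in the number. No measurement at hand gives a reason for this step.

The swap alters the ring and the way it is attached in one move, so the compounds shown cannot say which of the two accounts for the step. A 1-cyclohexylethyl group on the same nitrogen would change only the ring, and a pyridylmethyl group would show how a ring containing nitrogen fits this position.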